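Replacing 4-Fluorophenyl with 1-Methylindazolyl on a Shared Core

The compounds below may be only part of what the source reports. "The series", "measured", "known", "first", "only" and "open" are said of these compounds alone.

Compound 1 `COc1cc(-c2ccnc3cc(-c4ccc(F)cc4)nn23)cc(OC)c1OC`: 1280 nM
Compound 2 `COc1cc(-c2ccnc3cc(-c4cccc(C#N)c4)nn23)cc(OC)c1OC`: > 10000 nM

In a functional assay on MCF7 cells (Homo sapiens) for inhibition, read by CCK-8 assay, with a stated time of 48 h (a lower number here means a stronger inhibitor, a higher number a weaker inhibitor), compound 1 gives 1280 nM, the only number shown. The value of compound 2 is a limit of the assay (the limit of > 10000 nM in this assay, at which 1 of the 2 values shown sits). The step of an at least 7.8-fold higher number from compound 1 to compound 2 (0.89 log units; beyond the scatter) shows that changing this aryl group can weaken inhibition. Compound 3 `COc1cc(-c2ccnc3cc(-c4ccc5cnn(C)c5c4)nn23)cc(OC)c1OC` carries the change 1-methyl-1H-indazol-6-yl in place of 4-fluorophenyl on an aromatic carbon on the same core. This bears on the measured step only loosely, since a different group enters, so a modest weakening is expected: the estimated step is a 2.0-fold higher number from compound 1 to compound 3 (0.29 log units; within the scatter). Compound 3 is expected to give 2500 nM, between 900 nM and 8000 nM.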

Compound 3, half-maximal inhibitory concentration: 279 nM
The estimate for compound 3 lay 9.0-fold (0.95 log units) above the measured number; measured number outside the range, below it.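

In this assay, this aromatic carbon proves able to strengthen inhibition as well as weaken it: 1-methyl-1H-indazol-6-yl in place of 4-fluorophenyl gives a 4.6-fold lower number from compound 1 to compound 3 (0.66 log units; beyond the scatter). In place of 3-cyanophenyl, the same group gives an at least 35-fold lower number from compound 2 to compound 3 (1.55 log units; beyond the scatter). The value of compound 2 is a limit of the assay, so that step has no exact size: the limit of > 10000 nM in this assay, at which 1 of the 3 values shown sits.

The compounds shown do not separate the contributions of the five-membered aromatic ring, its two nitrogens and its methyl group. From the compounds shown here alone, how an indole or a 4-aminophenyl group would read at this carbon remains open.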